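The source may report more compounds than this note shows. Statements on the series, on what has been measured and on what is new or still open speak of the compounds shown alone.

Working notes on the series in a functional assay on HCT-116 cells (Homo sapiens) for antiproliferative activity, read by MTT assay, with a stated time of 24 h; on this read-out lower numbers stand for stronger inhibition and higher numbers for weaker inhibition. Compound 1 `COc1ccc(C(=O)/C=C/c2ccc(Br)cc2)c2c1C=CC(C)(C)O2` gives > 10000 nM, which is a limit of the assay. Compound 3 `COc1ccc(C(=O)/C=C/c2ccco2)c2c1C=CC(C)(C)O2` gives > 10000 nM, also only a limit, and it stands at the limit of > 10000 nM in this assay, at which 2 of the 3 values shown sit. Within the data shown here, compound 2 `COc1ccc(C(=O)/C=C/c2ccc(N(C)C)cc2)c2c1C=CC(C)(C)O2` gives 1920 nM, the only true number so far.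

Compound 4 `COc1ccccc1/C=C/C(=O)c1ccc(OC)c2c1OC(C)(C)C=C2` carries 2-methoxyphenyl in place of furan-2-yl on a double-bonded chain carbon bound to a double-bonded chain carbon.

The nearest measured changes are an at least 5.2-fold higher number from compound 2 to compound 3 (0.71 log units; beyond the scatter), an at least 5.2-fold lower number from compound 1 to compound 2 (0.71 log units; beyond the scatter) and a step that the two limits leave unreadable from compound 1 to compound 3. Only compound 2 at 1920 nM stands as a true number, so at most a modest fall in the number is expected, and possibly none: an at least 1.2-fold lower number from compound 3 to compound 4 (0.09 log units; that floor lies within the scatter). Compound 4 is expected at 8000 nM, within an estimated range of 2500 nM to 20000 nM.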

Compound 4, half-maximal inhibitory concentration: > 10000 nM
Compound 4: only a limit was reported; the forecaster's own chance of this, stated with the estimate: 50%; middle value at least 1.2-fold (0.09 log units) away from the limit.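

Among these compounds, at this position 2-methoxyphenyl also reads only as a limit of the assay, so 4-(dimethylamino)phenyl remains the only group here with a true number: the limit of > 10000 nM in this assay, at which 3 of the 4 values shown sit. Putting 2-methoxyphenyl in place of 4-(dimethylamino)phenyl gives an at least 5.2-fold higher number from compound 2 to compound 4 (0.71 log units; beyond the scatter). The steps from compound 3 to compound 4 and from compound 1 to compound 4 cannot be read.

As far as these compounds go, how compounds 1, 3 and 4 truly rank stays open. Also open, from the compounds shown here alone, is whether another amine on the aromatic ring, such as morpholine or diethylamino, would give a true number as compound 2 does.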